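The source may hold more compounds than are shown below. What is called first, only, known or untested is meant among the compounds shown, and "the series" means these compounds.

Compound 3 `COc1ccc(C=C2C(=O)N(c3ccc(Cl)cc3)N(c3ccc(Cl)cc3)C2=O)cc1` stands at the weak end of this small series. In a functional assay on MCF7 cells (Homo sapiens) for cytotoxicity, read by MTT assay, with a stated time of 72 h (a lower number here means a stronger inhibitor, a higher number a weaker inhibitor), compound 3 gives > 128000 nM, which is a limit and not a number. Compound 1 `O=C1C(=Cc2ccc(Cl)cc2)C(=O)N(c2ccc(Cl)cc2)N1c1ccc(Cl)cc1` gives 28500 nM and compound 2 `COc1cccc(C=C2C(=O)N(c3ccc(Cl)cc3)N(c3ccc(Cl)cc3)C2=O)c1O` gives 26700 nM, and the two lie within the scatter, with a 1.1-fold lower number from compound 1 to compound 2 (0.03 log units; within the scatter). Compound 4 `O=C1C(=Cc2ccc(Cl)cc2Cl)C(=O)N(c2ccc(Cl)cc2)N1c1ccc(Cl)cc1` has 2,4-dichlorophenyl in place of 4-methoxyphenyl on a double-bonded chain carbon bound to a double-bonded ring carbon.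

Among the measured compounds shown here, two measured steps bear on this change: an at least 4.4-fold higher number from compound 1 to compound 3 (0.65 log units; beyond the scatter), and an at least 4.7-fold higher number from compound 2 to compound 3 (0.68 log units; beyond the scatter). Both are beyond the scatter, and both are only lower bounds on the size of the step. Leaving the 4-methoxyphenyl is therefore expected to give a lower number in this assay, by a step beyond the scatter, with compound 1 at 28500 nM as the closest guide. The estimated step is an at least 4.9-fold lower number from compound 3 to compound 4 (0.69 log units; beyond the scatter). For compound 4 the estimated value is 26000 nM, with an expected range of 10000 nM to 70000 nM.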

Compound 4, half-maximal inhibitory concentration: > 128000 nM
Compound 4: only a limit was reported (the forecaster's own chance of this, stated with the estimate: 15%); middle value at least 4.9-fold (0.69 log units) away from the limit.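

In this assay, chloro in place of hydrogen on an aromatic carbon gives an at least 4.4-fold higher number from compound 1 to compound 4 (0.65 log units; beyond the scatter), so a readable value at this place does not carry over from 4-chlorophenyl to 2,4-dichlorophenyl. 2,4-Dichlorophenyl in place of 2-hydroxy-3-methoxyphenyl gives an at least 4.7-fold higher number from compound 2 to compound 4 (0.68 log units; beyond the scatter), so the move to the limit is not confined to 4-methoxyphenyl and also occurs with a group carrying only chlorine. The step between compound 3 and compound 4 cannot be read, as both values are limits and not numbers: the limit of > 128000 nM in this assay, at which 2 of the 4 values shown sit.

As far as these compounds go, how far compound 3 and compound 4 lie past their limits remains open. Also open, from the compounds shown here alone, is whether a 4-aminophenyl or a 4-carboxyphenyl on the double-bonded chain carbon would give a readable value.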